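Bromo for methyl on the thioether aryl of compound 1

The compounds below may be only part of what the source reports. "The series", "measured", "known", "first", "only" and "open" are said of these compounds alone.

Measured so far:
- compound 1 `C#CCNC1CCc2c(SCc3cccc(C)c3)cccc21` gives > 100000 nM in an assay on isolated protein for inhibition of Amine oxidase [flavin-containing] B (Homo sapiens); on this read-out higher numbers stand for weaker inhibition and lower numbers for stronger inhibition
- compound 2 `C#CCNC1CCc2c(SCCc3cccc(C(F)(F)F)c3)cccc21` gives 3720 nM in this assay
- compound 3 `C#CCNC1CCc2c(SCc3ccc(Cl)cc3Cl)cccc21` gives 3760 nM in this assay

Compound 1 stands at the limit of this assay; its value is a limit of the assay and not a number. The other two values, those of compound 2 and compound 3, sit within the scatter of each other, so no order between them is claimed.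

Compound 4 is `C#CCNC1CCc2c(SCc3cccc(Br)c3)cccc21`. It differs from compound 1 by bromo in place of methyl on an aromatic carbon, on an aromatic carbon of a six-membered aromatic ring of carbon only, meta to a large group. Among the measured compounds shown here, with compound 1 at the limit, no measured step tells how large the change from compound 1 to compound 4 is; the step can only be estimated from the limit. The halogen-bearing compound 3 gives a measurable value, and compound 4 is expected to fall nearer to that, so the step from compound 1 to compound 4 is estimated as an at least 6.6-fold lower number from compound 1 to compound 4 (0.82 log units; beyond the scatter), toward stronger inhibition. For compound 4 the expected value in this assay is 15000 nM, with a range from 2500 nM to 90000 nM.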

Compound 4, half-maximal inhibitory concentration: > 100000 nM
Compound 4: no number, only a limit; the forecaster's own chance of this, stated with the estimate: 35%; middle value at least 6.6-fold (0.82 log units) away from the limit.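

No step can be read between compound 1 and compound 4, since each gives only a limit of the assay and not a number: the limit of > 100000 nM in this assay, at which 2 of the 4 values shown sit.

Left open is whether 3-methylphenyl and 3-bromophenyl differ at all in inhibition, and if so, by how much.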